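The source may report more compounds than this note shows. Statements on the series, on what has been measured and on what is new or still open speak of the compounds shown alone.

Compound 1 `Cc1nc(C)n(CC(=O)N2CCN(c3sc(C(F)(F)F)nc3-c3nc4ccc(C5CCOCC5)cc4[nH]3)C[C@H]2C)n1` is the stronger of the two compounds with a result: in a functional assay on Venous blood for antagonist activity at C-X-C chemokine receptor type 3 (Homo sapiens), read by flow cytometry, with a stated time of 30 min, in the presence of a further agent that is not named here (a lower number here means a stronger inhibitor, a higher number a weaker inhibitor), compound 1 gives 123 nM. Compound 2 `Cc1nc(C)n(CC(=O)N2CCN(c3sc(C(F)(F)F)nc3-c3nc4ccc(OC5CNC5)cc4[nH]3)C[C@H]2C)n1` carries (azetidin-3-yl)oxy in place of oxan-4-yl on an aromatic carbon, and in this assay compound 2 gives 580 nM; the change brings a 4.7-fold higher number from compound 1 to compound 2 (0.67 log units; beyond the scatter). Among the measured compounds shown here, compound 1 therefore stands lowest of the two numbers, with compound 2 the only neighbour.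

Compound 3 `Cc1nc(C)n(CC(=O)N2CCN(c3sc(C(F)(F)F)nc3-c3nc4ccccc4[nH]3)C[C@H]2C)n1` differs from compound 1 by hydrogen in place of oxan-4-yl on an aromatic carbon. For the measured compounds named here, the single measured step bears on this only indirectly, since it swaps the oxan-4-yl for another group rather than removing it, yet it shows that altering this position can move the number beyond the scatter. Loss of the group is expected to weaken inhibition modestly, by about a 2.6-fold higher number from compound 1 to compound 3 (0.42 log units; beyond the scatter). Compound 3 is estimated at 320 nM, within a range of 120 nM to 900 nM.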

Compound 3, half-maximal inhibitory concentration in the C-X-C chemokine receptor type 3 assay: 237 nM
For compound 3 the middle estimate is 1.4-fold (0.13 log units) above the measured one; the measured number falls inside the stated range.
By their numbers in the C-X-C chemokine receptor type 3 assay, from the lowest: compounds 1 and 3 (each within the scatter of the next); then compound 2.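

In the C-X-C chemokine receptor type 3 assay, hydrogen in place of oxan-4-yl gives a 1.9-fold higher number from compound 1 to compound 3 (0.28 log units; within the scatter), while hydrogen in place of (azetidin-3-yl)oxy gives a 2.4-fold lower number from compound 2 to compound 3 (0.39 log units; beyond the scatter), so this aromatic carbon needs no added ring to keep the number of compound 1, and of the two groups tried only (azetidin-3-yl)oxy leaves a weaker inhibitor than plain hydrogen. In a physicochemical assay for solubility, in simulated intestinal fluid (on this read-out higher numbers stand for higher solubility and lower numbers for lower solubility), compound 1 gives > 1000 ug/mL, which is a limit of the assay and not a number. In the physicochemical assay compound 3 gives > 850 ug/mL, which is also a limit.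

As far as these compounds go, the step between these two limits cannot be read, so any effect of oxan-4-yl on solubility stays open. Also open, from the compounds shown here alone, is whether a small amine or a carboxylic acid on this aromatic carbon would give a stronger inhibitor than hydrogen does.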